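Swapping cyclohexyl for 2-methoxyethyl in compound 1

This account rests on a few compounds, and the source may have more. Where it says the series, first, only, none or still open, it means among the compounds named here.

- Compound 1 `C[N+]1(CC2CCCCC2)CCc2c(sc(NC(=O)Nc3ccc(Cl)cc3)c2C(N)=O)C1` gives 100 nM
- Compound 2 `CCN1CCc2c(sc(NC(=O)Nc3ccc4ccccc4c3)c2C(N)=O)C1` gives 1780 nM

In a functional assay (strain AB) with Danio rerio as the target, read by microscopy, with a stated time of 1 h (on this read-out lower numbers stand for an effect already at smaller amounts and higher numbers for an effect only at larger amounts of compound), compound 1 stands lowest of the two numbers at 100 nM so far, and compound 2 sits higher at 1780 nM with a gap beyond the scatter. These two compounds differ in more than one place, so no single change can be read from them. Compound 3 `COCCC[N+]1(C)CCc2c(sc(NC(=O)Nc3ccc(Cl)cc3)c2C(N)=O)C1` keeps the core of compound 1 and alters one side chain: 2-methoxyethyl in place of cyclohexyl on a saturated chain carbon bound to an amine nitrogen in a ring with 2-methoxyethyl in place of cyclohexyl on a saturated chain carbon bound to an amine nitrogen in a ring. Going by the values given here, no measured pair tests this change. Compound 1 already holds the lowest number at 100 nM so far, so a move upward seems the likelier outcome. The estimated step is a 3.0-fold higher number from compound 1 to compound 3 (0.48 log units; beyond the scatter) toward a higher number and beyond the scatter. For compound 3 the estimated value is 300 nM and the expected range runs from 90 nM to 1200 nM on this estimate.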

Compound 3, half-maximal effective concentration: 480 nM
Compound 3: the middle estimate sits 1.6-fold (0.20 log units) below what was measured; low and high end bracket the measured number.
By their numbers in this assay, from the lowest: compound 1; then compound 3; then compound 2.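

Going by these compounds alone, this is the only comparison so far that changes a single place. With the rest of compound 1 held fixed in this assay, putting 2-methoxyethyl in place of cyclohexyl on a saturated chain carbon bound to an amine nitrogen in a ring gives a 4.8-fold higher number from compound 1 to compound 3 (0.68 log units; beyond the scatter). The read-out therefore responds to this side chain, and the open chain with its oxygen still gives an effect, though only at a larger amount of compound than the carbon ring needs. No measurement available here links this shift to any property of the two groups.

From the compounds shown here alone, the swap removes the ring and adds the oxygen together, so the share of each remains open. A plain butyl chain at this place could separate the two, and an amine at the chain's end would test a different kind of group.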